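Cytotoxicity notes on a 2-cyanophenyl amide variant

The source may hold more compounds than are shown below. What is called first, only, known or untested is meant among the compounds shown, and "the series" means these compounds.

Measured compounds:
Compound 1 `COc1ccc(-c2cnc(NC(=O)c3ccc(Br)cc3)n2C)cc1` gives > 100000 nM in a toxicity assay on THP-1 cells (Homo sapiens) for inhibition; on this read-out lower numbers stand for higher toxicity in this test and higher numbers for lower toxicity in this test; this value is a limit of the assay.
Compound 2 `Cn1c(-c2ccccc2F)cnc1NC(=O)c1ccc(F)cc1` gives > 100000 nM in this assay; this value is a limit of the assay.
Compound 3 `Cn1c(-c2ccccc2)cnc1NC(=O)c1ccc(Br)cc1` gives > 100000 nM in this assay; this value is a limit of the assay.

Compound 1 therefore stands at the upper limit of this assay, not at a number, and the same holds for every value shown, due to the limit of > 100000 nM in this assay, at which 3 of the 3 values shown sit. Among the compounds with values here, the only single-site comparison among the measured compounds, a step that the two limits leave unreadable from compound 1 to compound 3, runs between two limits and its size cannot be read; it shows no more than that hydrogen in place of methoxy on an aromatic carbon left compound 3 at the limit as well. Within the data shown here, compound 2 likewise sits at the limit, but it differs from the others in more than one place and gives no step.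

The new compound 4 `COc1ccc(-c2cnc(NC(=O)c3ccccc3C#N)n2C)cc1` arises from compound 1 through (2-cyanophenyl in place of 4-bromophenyl on a carbonyl carbon). Among the measured compounds shown here, no measured step touches the aryl group on the carbonyl carbon, so no direction can be drawn from the data; what the series shows is that three variations at two other sites all remained at the limit. On that basis compound 4 is expected to remain at the limit too, with a number no higher from compound 1 to compound 4 (the limit leaves the size open) estimated as no step beyond the scatter. The estimate for compound 4 in this assay is 100000 nM, expected to lie between 30000 nM and 300000 nM.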

Compound 4, half-maximal cytotoxic concentration: > 100000 nM
Compound 4 gave a limit, no number; the forecaster's own chance of this, stated with the estimate: 80%; the middle value sits exactly at the limit.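

Within the data shown here, compound 1 and compound 4 are both limits rather than numbers in this assay, so the step between them cannot be read and no new step arises. The whole series sits at this one limit: the limit of > 100000 nM in this assay, at which 4 of the 4 values shown sit. The compounds shown leave open how far each lies past that limit and which structural change, if any, would give a readable number.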